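Chloro for nitro in a triazene series

This account rests on a few compounds, and the source may have more. Where it says the series, first, only, none or still open, it means among the compounds named here.

Going by the values given here, three aryl- and heteroaryl-triazenes carry numbers so far. Compound 1, `CN(C)/N=N/c1ccccc1[N+](=O)[O-]`, gives 3.28 in a functional assay on L1210 cells (Mus musculus) for antiproliferative activity (a lower number here means a less potent compound, a higher number a more potent compound, by a factor of ten per unit of this negative logarithm), the lowest of the three. Compound 3, `CN(C)/N=N/c1n[nH]cc1C(N)=O`, gives 3.49 in this assay, a number within the scatter of that of compound 1, so the two cannot be told apart. Compound 2, `CCCCN(C)/N=N/c1c(C(N)=O)n[nH]c1C`, gives 3.83, and this one does stand beyond the scatter above compound 1. Among the compounds with values here, no pair of these differs in a single place, so no step between measured compounds can be read off.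

The unmeasured compound 4, `CN(C)/N=N/c1ccccc1Cl`, is reached from compound 1 by one change: chloro in place of nitro on an aromatic carbon. The change sits on an aromatic carbon of a six-membered aromatic ring of carbon only, ortho to a group of 5 heavy atoms.

Within the data shown here, no measured step tells what this exchange does. The account therefore expects the step from compound 1 to compound 4 to be small, a number 0.12 log units higher from compound 1 to compound 4 (within the scatter), within the scatter. For compound 4 it estimates 3.4 in this assay, in the range 2.8 to 4.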

Compound 4, logarithm of the reciprocal of the active concentration, log(1/C): 3.26
Compound 4: the middle estimate sits 0.14 log units above what was measured; measured number inside the range.
By their numbers in this assay, from the lowest: compounds 4, 1 and 3 (each within the scatter of the next); then compound 2.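

Going by these compounds alone, this is the first step that can be read: in this assay the exchange gives a number 0.02 log units lower from compound 1 to compound 4 (within the scatter), so the two compounds cannot be told apart. On this aromatic carbon, then, a nitro group with 3 heavy atoms and 2 hydrogen-bond acceptors and a chloro group with 1 heavy atom and no hydrogen-bond acceptors give numbers within the scatter of each other, a finding that rests on this single pair. No measurement at hand bears on what lies behind this result.

From the compounds shown here alone, whether an amine or a carboxylic acid in place of the nitro of compound 1 would also stay within the scatter remains open. So does whether chloro in place of nitro would give as small a step on any other core.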